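The source may hold more compounds than are shown below. What is called first, only, known or untested is meant among the compounds shown, and "the series" means these compounds.

Measured so far:
Compound 2 `O=C(Nc1ccc(Nc2ccc([N+](=O)[O-])c3ncnc(O)c23)cc1)c1ccccc1`: 65300 nM
Compound 3 `Cc1ccc(C(=O)Nc2ccc(Nc3ccc([N+](=O)[O-])c4ncnc(O)c34)cc2)cc1`: 93200 nM
Compound 1 `O=C(Nc1cccc(Nc2ccc([N+](=O)[O-])c3ncnc(O)c23)c1)c1ccc(Cl)cc1`: no number reported

These three compounds share one core and differ only in the benzamide end. For compound 1 the result in an ADME assay on L02 cells (Homo sapiens) for cytotoxicity (a higher number here means a weaker inhibitor, a lower number a stronger inhibitor), is "not determined" (no result reported), so it adds no number to compare. Going by the values given here, compound 3 gives one of only two numbers in this assay, and the step of a 1.4-fold higher number from compound 2 to compound 3 (0.15 log units; within the scatter) is within the scatter, so compound 3 and compound 2 cannot be told apart on this read-out.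

Compound 4 `O=C(Nc1ccc(Nc2ccc([N+](=O)[O-])c3ncnc(O)c23)cc1)c1ccc(Cl)cc1` is the next step: chloro in place of methyl on an aromatic carbon. Among the compounds with values here, no measured pair shows this exchange, and the one measured step, a 1.4-fold higher number from compound 2 to compound 3 (0.15 log units; within the scatter), concerns a different swap at the same place and was itself within the scatter. On that basis no shift beyond the scatter is expected for compound 4 in this assay, and the step of a 1.2-fold lower number from compound 3 to compound 4 (0.07 log units; within the scatter) is an estimate that stays close to compound 3. Compound 4 is therefore expected to give about 80000 nM, with a range from 35000 nM to 180000 nM.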

Compound 4, half-maximal inhibitory concentration: 73500 nM
Compound 4: middle estimate off by 1.1-fold (0.04 log units), on the high side; the measured number falls inside the stated range.
By their numbers in this assay, from the lowest: compounds 2, 4 and 3 (each within the scatter of the next).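

In this assay, replacing methyl with chloro at this ring carbon, para to a large group, gives a 1.3-fold lower number from compound 3 to compound 4 (0.10 log units; within the scatter) and replacing hydrogen with chloro at the same carbon gives a 1.1-fold higher number from compound 2 to compound 4 (0.05 log units; within the scatter) and neither step can be read as a real change. Hydrogen, methyl and chloro at this one place therefore give numbers that cannot be told apart, whereas the earlier compounds compared only hydrogen and methyl. Nothing measured here explains why these three groups read alike.

On these data alone, whether an amine, a carboxylic acid or a longer chain at this carbon would move the number beyond the scatter remains open. Compound 1 has no number in this assay so it cannot show whether a change elsewhere in the molecule matters more.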